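The compounds below may be only part of what the source reports. "The series", "measured", "known", "first", "only" and "open" are said of these compounds alone.

Values in a functional assay on MCF7 cells (Homo sapiens) for antiproliferative activity, read by MTT assay, with a stated time of 72 h; a lower number here means a stronger inhibitor, a higher number a weaker inhibitor:
- compound 1 `C/C=C/C(=O)Nc1cccc(Oc2nc(Nc3ccn(C)n3)nc3c2CSCC3)c1`: 40000 nM
- compound 2 `CC(C)/C=C/C(=O)Nc1cccc(Oc2nc(Nc3ccn(C)n3)nc3c2CSCC3)c1`: > 50000 nM, a limit of the assay and not a number
- compound 3 `C/C=C/C(=O)Nc1cccc(Oc2nc(Nc3cccc(OC)c3)nc3c2CSCC3)c1`: 23400 nM

Within the data shown here, only one other true number stands near compound 3: a 1.7-fold lower number from compound 1 to compound 3 (0.23 log units; within the scatter). That step changed the group on a nitrogen on an aromatic ring, so it says little here.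

Compound 4 `COc1cccc(Nc2nc3c(c(Oc4cccc(NC(=O)C=C(C)C)c4)n2)CSCC3)c1` differs from compound 3 on a carbonyl carbon: 2-methylprop-1-en-1-yl in place of prop-1-en-1-yl on a carbonyl carbon. The nearest guide is a different change on the same chain, isopropyl in place of methyl: an at least 1.2-fold higher number from compound 1 to compound 2 (0.09 log units; that floor lies within the scatter). It leans towards a higher number but stays within the scatter, so only a small rise, or none beyond the scatter, is expected in this assay.

The estimated step is a 1.4-fold higher number from compound 3 to compound 4 (0.15 log units; within the scatter).

For compound 4 the expected value is 33000 nM, with an estimated range from 17000 nM to 60000 nM.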

Compound 4, half-maximal inhibitory concentration: > 50000 nM
Compound 4: a limit, no number; the forecaster's own chance of this, stated with the estimate: 35%; at least 1.5-fold (0.18 log units) between middle value and limit.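

In this assay, swapping prop-1-en-1-yl for 2-methylprop-1-en-1-yl on the carbonyl carbon gives an at least 2.1-fold higher number from compound 3 to compound 4 (0.32 log units; beyond the scatter). This is the first change on this chain shown to go beyond the scatter, whereas the step between compound 1 and compound 2 had a floor within it. The value of compound 4 is a limit of the assay, so this step gives only a minimum size: the limit of > 50000 nM in this assay, at which 2 of the 4 values shown sit.

Still open, on these data alone, is how a longer chain on this carbonyl carbon, or an amine at the end of the chain, would read. As far as these compounds go, the true values of compound 2 and compound 4 also remain unknown.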